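A few compounds are considered here, and "the series" means these few. Any claim that something is new, unique, unknown or untested is made for them only; others in the source may bear on it.

Working notes on the series. Compound 1 `O=C(O)c1cccc(CCCCCCC(=O)c2ncc(-c3ccccn3)o2)c1` in an assay for inhibition of Fatty-acid amide hydrolase 1 (Rattus norvegicus) (a lower number here means a stronger inhibitor, a higher number a weaker inhibitor), gives only a limit, > 600 nM, not a number. Compound 2 `O=C(O)c1ccc(CCCCCCC(=O)c2ncc(-c3ccccn3)o2)cc1` in this assay likewise gives only a limit, > 600 nM. Compound 3 `O=C(CCCCCCc1cccc(Cl)c1Cl)c1ncc(-c2ccccn2)o1` in this assay gives 0.9 nM, the one number shown. The other two values, those of compound 1 and compound 2, sit at the limit of > 600 nM in this assay, at which 2 of the 3 values shown sit. The steps of an at least 660-fold lower number from compound 1 to compound 3 (2.82 log units; beyond the scatter) and an at least 660-fold lower number from compound 2 to compound 3 (2.82 log units; beyond the scatter) are each beyond the scatter and readable only as floors; the step that the two limits leave unreadable from compound 1 to compound 2 cannot be read.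

Compound 4 `COc1ccc(CCCCCCC(=O)c2ncc(-c3ccccn3)o2)cc1` differs from compound 3 by 4-methoxyphenyl in place of 2,3-dichlorophenyl on a saturated chain carbon, six bonds along the chain from a carbonyl carbon. Within the data shown here, no measured step exchanges one group without net charge for another; the two steps that bear on it swap a carboxyphenyl for the 2,3-dichlorophenyl and show only that the gain is large. The entering 4-methoxyphenyl, like the leaving group, carries no net charge, so compound 4 is expected to stay well inside the measurable range, nearer to compound 3 than to the limit compounds, with a moderate loss expected, an 11-fold higher number from compound 3 to compound 4 (1.05 log units; beyond the scatter). Compound 4 is estimated at 10 nM, in the range 1.5 nM to 70 nM.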

Compound 4, inhibition constant: 6.2 nM
Compound 4: the middle estimate sits 1.6-fold (0.21 log units) above what was measured; the measured number falls inside the stated range.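

Among these compounds, the first exchange here between two groups with no net charge gives a 6.9-fold higher number from compound 3 to compound 4 (0.84 log units; beyond the scatter) in this assay, so this position now has a step that reads as a size and not only as a floor. That step is modest, so this position accepts a 4-methoxyphenyl as well as a 2,3-dichlorophenyl with a number still far from the limit compounds. Methoxy in place of carboxy gives an at least 96-fold lower number from compound 2 to compound 4 (1.98 log units; beyond the scatter) and the exchange from 3-carboxyphenyl gives an at least 96-fold lower number from compound 1 to compound 4 (1.98 log units; beyond the scatter), and both remain floors, compound 1 and compound 2 each giving a limit and not a number: the limit of > 600 nM in this assay, at which 2 of the 4 values shown sit.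

Going by these compounds, whether the step to compound 4 follows the loss of the chlorines or the gain of the methoxy stays open, as one exchange changes both. The compounds shown also leave open how an unsubstituted phenyl, a methyl ester of the carboxylic acid, an amine or a longer chain would read at this position.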